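Swapping phenyl for pyridin-2-yl on the core

The compounds below may be only part of what the source reports. "The series", "measured", "known", "first", "only" and "open" are said of these compounds alone.

Of the compounds shown here, two have been measured so far. Compound 1 `CC(C)(C)C1=NN(c2cccc(Cl)c2)C(c2ccc(O)cc2)C1` gives 96.8% in an assay on isolated protein for inhibition of protein kinase C zeta type (Homo sapiens), with a stated time of 4 min, tested at 62.5 uM; on this read-out higher numbers stand for more inhibition at the one concentration tested (going by the name of the read-out) and lower numbers for less inhibition. Compound 2 `Oc1ccc(C2CC(c3ccccc3)=NN2c2cccc(Cl)c2)cc1` gives 90.5% in this assay. Among the compounds with values here, compound 2 therefore holds the lower of the two numbers, but the only step connecting the pair, a number 6.3 percentage points lower from compound 1 to compound 2 (within the scatter), lies within the scatter, so the two values cannot be told apart.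

The next compound, compound 3 `Oc1ccc(C2CC(c3ccccn3)=NN2c2cccc(Cl)c2)cc1`, differs from compound 2 in a single place: pyridin-2-yl in place of phenyl on a carbon with a double bond to nitrogen. Within the data shown here, no measured step involves a pyridin-2-yl group, so the only guide is the one step on the same carbon, the change from tert-butyl to phenyl, which moved the read-out by an amount within the scatter. Both measured values sit near the top of the scale, leaving little room for a rise. The step of a number 2.5 percentage points lower from compound 2 to compound 3 (within the scatter) is therefore expected to stay within the scatter, with no direction that can be read from the data. For compound 3 the estimate in this assay is 88%, with a range from 68% to 99%.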

Compound 3, a percentage reported as inhibition, at one concentration (the size of the read-out at that concentration, not a potency): 82.2%
The estimate for compound 3 lay 5.8 percentage points above the measured number; low and high end bracket the measured number.
By their numbers in this assay, from the lowest: compounds 3, 2 and 1 (each within the scatter of the next, the first and the last beyond it).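

At the carbon with a double bond to nitrogen, exchanging phenyl for pyridin-2-yl, a ring with one nitrogen and one hydrogen-bond acceptor by count, gives a step that cannot be told from the usual spread of repeat measurements in this assay (a number 8.3 percentage points lower from compound 2 to compound 3 (within the scatter)). Within the data shown here, the comparison with tert-butyl at the same carbon gives the first step at this position that lies beyond that spread, though only a modest one (a number 14.6 percentage points lower from compound 1 to compound 3 (beyond the scatter)), so the position is not wholly indifferent to the group it carries, even though compound 2 cannot be separated from either compound 1 or compound 3. No measurement here accounts for this difference.

On these data alone, with only tert-butyl, phenyl and pyridin-2-yl compared, it remains open how an amine, a carboxylic acid or a longer chain on this carbon would behave, and whether the modest step from tert-butyl to pyridin-2-yl would hold up against other groups. As far as these compounds go, each number also comes from a single concentration, so how these compounds would compare across a range of concentrations remains unknown.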